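A few compounds are considered here, and "the series" means these few. Any claim that something is new, unique, unknown or untested is made for them only; others in the source may bear on it.

Measured compounds in the series:

compound 1 `COc1ccc(/C=C/C(=O)c2c(C)[n+]([O-])c3ccccc3[n+]2[O-])cc1OC` – 31000 nM
compound 2 `Cc1c(C(=O)/C=C/c2ccc(Cl)c(Cl)c2)[n+]([O-])c2ccccc2[n+]1[O-]` – 84000 nM
compound 3 `COc1cc(/C=C/C(=O)c2c(C)[n+]([O-])c3ccccc3[n+]2[O-])cc(OC)c1OC` – 6600 nM

In a functional assay on HSC-3 cells (Homo sapiens) for cytotoxicity, with a stated time of 48 h (on this read-out lower numbers stand for higher toxicity in this test and higher numbers for lower toxicity in this test), compound 2 gives the highest number of the three measured compounds. Compound 1 lies nearest to it and compound 3 furthest, and both of these gaps are beyond the scatter. Among the compounds with values here, the only step between two measured compounds that differ in one place is a 4.7-fold lower number from compound 1 to compound 3 (0.67 log units; beyond the scatter), which concerns a methoxy in place of hydrogen on an aromatic carbon and says nothing about the exchange of one halogen-bearing aryl group for another.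

Compound 4 `Cc1c(C(=O)/C=C/c2ccc(Br)cc2)[n+]([O-])c2ccccc2[n+]1[O-]` differs from compound 2 in one place: 4-bromophenyl in place of 3,4-dichlorophenyl on a double-bonded chain carbon bound to a double-bonded chain carbon. Within the data shown here, no measured pair in this set bears on such a change; the values of compound 1, compound 2 and compound 3 show only that substituents on this aryl group move the read-out by modest amounts. A step within the scatter is therefore expected from compound 2 to compound 4, a 1.4-fold lower number from compound 2 to compound 4 (0.15 log units; within the scatter), with no direction favoured. Compound 4 is estimated at 60000 nM in this assay, with a range from 20000 nM to 180000 nM.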

Compound 4, half-maximal cytotoxic concentration: 56000 nM
Compound 4: middle estimate off by 1.1-fold (0.03 log units), on the high side; measured number inside the range.
By their numbers in this assay, from the lowest: compound 3; then compounds 1, 4 and 2 (each within the scatter of the next, the first and the last beyond it).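

In this assay, within the data shown here, 4-bromophenyl in place of 3,4-dichlorophenyl on a double-bonded chain carbon bound to a double-bonded chain carbon gives a 1.5-fold lower number from compound 2 to compound 4 (0.18 log units; within the scatter), the first step between two halogen-bearing aryl groups. For this pair, the exchange of two chlorine atoms for one bromine on the aryl group therefore gives no difference that can be told from the scatter, whereas the methoxy step, a 4.7-fold lower number from compound 1 to compound 3 (0.67 log units; beyond the scatter), lies beyond it. No measurement is available that accounts for either outcome.

Halogen kind and halogen number change together in this single pair, so their separate contributions remain open. Also open, on these data alone, is how this assay would read with a dimethylamino group or a carboxylic acid on the aryl group in place of the halogens or methoxy groups.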